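Swapping the piperidinyloxy arm of a chromone for a fluoropyridyl

The source may report more compounds than this note shows. Statements on the series, on what has been measured and on what is new or still open speak of the compounds shown alone.

Measured so far:
compound 1 `COc1cc(OC)c2c(=O)cc(-c3ccc(OC4CCNCC4)cc3)oc2c1`: 21%
compound 2 `COc1cc(OC)c2c(=O)cc(-c3ccc(Br)cc3)oc2c1`: 10%

Compound 1 stands highest of the two numbers in a functional assay (Homo sapiens) for antiproliferative activity, read by resazurin assay, with a stated time of 48 h, tested at 10 uM; a higher number here means a stronger effect of the compound at the concentration tested, a lower number a weaker effect; compound 2 is nearest, and the step is a number 11 percentage points lower from compound 1 to compound 2 (beyond the scatter). The new compound 3 `COc1cc(OC)c2c(=O)cc(-c3ccc(-c4ccc(F)nc4)cc3)oc2c1` differs from compound 1 as follows: 6-fluoropyridin-3-yl in place of (piperidin-4-yl)oxy on an aromatic carbon. Going by the values given here, only one measured step bears on this change: the step from compound 1 to compound 2 also removes the (piperidin-4-yl)oxy group, with a modest loss, a number 11 percentage points lower from compound 1 to compound 2 (beyond the scatter). Among the compounds with values here, compound 3 loses the same group and gains a 6-fluoropyridin-3-yl instead; no measured pair shows what that incoming group contributes. Compound 3 is therefore expected to fall somewhat, by a number 8 percentage points lower from compound 1 to compound 3 (within the scatter), since it shares the loss seen in a number 11 percentage points lower from compound 1 to compound 2 (beyond the scatter). The estimate for compound 3 in this assay is 13%, expected to lie between 0% and 30%.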

Compound 3, a percentage reported as inhibition, at one concentration (the size of the read-out at that concentration, not a potency): 6%
Beside the measured number, compound 3's estimate is 7 percentage points above it, and the stated range covers the measured number.
By their numbers in this assay, from the lowest: compounds 3 and 2 (each within the scatter of the next); then compound 1.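

In this assay, 6-fluoropyridin-3-yl in place of (piperidin-4-yl)oxy gives a number 15 percentage points lower from compound 1 to compound 3 (beyond the scatter), so a second, different replacement at this position also ends beyond the scatter below compound 1. Exchanging bromo for 6-fluoropyridin-3-yl gives a number 4 percentage points lower from compound 2 to compound 3 (within the scatter), so these two incoming groups, a halogen and an aromatic ring, cannot be told apart in this assay. Nothing available explains why compound 1 stands above both.

The compounds shown leave open whether the difference rests on the piperidine nitrogen or on the ether oxygen, a question that a cyclohexyloxy group or an open-chain 2-aminoethoxy group at this position would address. They also leave open how these read-outs at a single concentration relate to potency.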